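The source may report more compounds than this note shows. Statements on the series, on what has been measured and on what is new or still open speak of the compounds shown alone.

Measured so far:
- Compound 1 `Clc1cc(Cl)cc(CO[C@H]2CCCN(Cc3ccccc3)[C@H]2c2ccccc2)c1`: in an assay on isolated protein for activation of cGMP-dependent protein kinase 1 (Homo sapiens), read by ADP-Glo, with stated times of 120 min and 40 min (on this read-out lower numbers stand for an effect already at smaller amounts and higher numbers for an effect only at larger amounts of compound), compound 1 gives > 200000 nM, which is a limit of the assay and not a number.
- Compound 2 `O=C(O)c1ccc2c(CN3CCC[C@H](O[C@H](CO)c4cc(Cl)cc(Cl)c4)[C@@H]3c3ccccc3)c[nH]c2c1`: in this assay compound 2 gives 22000 nM.

From the compounds shown here alone, compound 1 stands only at the limit of > 200000 nM in this assay, at which 1 of the 2 values shown sits; its true value is unknown. Compound 3 `Cn1ccnc1CN1CCC[C@H](OCc2cc(Cl)cc(Cl)c2)[C@@H]1c1ccccc1` is not yet measured and differs from compound 1 thus: 1-methyl-1H-imidazol-2-yl in place of phenyl on a saturated chain carbon bound to an amine nitrogen in a ring. Going by the values given here, no measured pair covers this change, so the expected step in this assay from compound 1 to compound 3 is taken as small, an at least 1.3-fold lower number from compound 1 to compound 3 (0.12 log units; that floor lies within the scatter), with no clear direction beyond the scatter. Compound 3 is therefore estimated at 150000 nM, within 40000 nM to 600000 nM.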

Compound 3, half-maximal effective concentration: 165000 nM
For compound 3 the middle estimate is 1.1-fold (0.04 log units) below the measured one; low and high end bracket the measured number.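

Going by these compounds alone, with 1-methyl-1H-imidazol-2-yl in place of phenyl, compound 3 gives a real number in this assay, 165000 nM, so this position now has a first quantified value for an unsubstituted-core side group without an acid. The change reads only as an at least 1.2-fold lower number from compound 1 to compound 3 (0.08 log units; that floor lies within the scatter), so no gain can be claimed. Its true size stays open because compound 1 stands at a limit of the assay, not a number: the limit of > 200000 nM in this assay, at which 1 of the 3 values shown sits.

Open, from the compounds shown here alone, is whether pyridin-2-yl or thiazol-2-yl in the same place would move the number beyond the scatter. A carboxylic acid on this imidazole is also untested here.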